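The compounds below may be only part of what the source reports. "The series", "measured", "known", "first", "only" and "open" are said of these compounds alone.

Of the compounds shown here, three have so far been tested in a functional assay on NCI-H460 cells (Homo sapiens) for antiproliferative activity, with a stated time of 72 h; on this read-out lower numbers stand for stronger inhibition and higher numbers for weaker inhibition. Compound 1 `C=CC[C@H]1C[C@]2([C@@H](C)Cc3ccc(OC)c(OC)c3)OCOC2=CC1=O` gives 260 nM, the lowest of the two numbers recorded. Compound 3 `C=CC[C@H]1C[C@]2([C@@H](C)Cc3cccc(OC)c3)OCOC2=CC1=O`, which carries a hydrogen in place of methoxy on an aromatic carbon, gives 10600 nM, so there is a 41-fold higher number from compound 1 to compound 3 (1.61 log units; beyond the scatter). Compound 2 `C=CC[C@@H]1C[C@]2([C@@H](C)Cc3ccc(OC)c(OC)c3)OCOC2=CC1=O` reached only the limit of the assay, > 4000 nM. Compound 2 has the same atoms and bonds as compound 1 and differs only in the drawn configuration at one saturated ring carbon, yet there is an at least 15-fold higher number from compound 1 to compound 2 (1.18 log units; beyond the scatter), a step whose exact size is hidden by the limit of > 4000 nM in this assay, at which 1 of the 3 values shown sits.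

Compound 4 `C=CC[C@H]1C[C@]2([C@@H](C)Cc3ccc(OC)c(O)c3)OCOC2=CC1=O` is not yet measured. It differs from compound 1 in one place: hydrogen in place of methyl on an oxygen on an aromatic ring. Read one bond further out, the change is methoxy to hydroxy, so the oxygen stays and only its methyl leaves. For the measured compounds named here, no measured step repeats this change. The nearest is the removal of the whole methoxy, which gave a 41-fold higher number from compound 1 to compound 3 (1.61 log units; beyond the scatter); since compound 4 keeps the oxygen, a smaller rise is expected. The step from compound 1 to compound 2 concerns configuration and does not bear on this change. Compound 4 is therefore expected to give 1500 nM in this assay, between 400 nM and 6000 nM, an expected step of a 5.8-fold higher number from compound 1 to compound 4 (0.76 log units; beyond the scatter).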

Compound 4, half-maximal inhibitory concentration: 80 nM
Compound 4: middle estimate off by 19-fold (1.27 log units), on the high side; measured number below the stated range.
By their numbers in this assay, from the lowest: compound 4; then compound 1; then compound 3.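

Taking the methyl off this oxygen and leaving a hydroxy gives a 3.3-fold lower number from compound 1 to compound 4 (0.51 log units; beyond the scatter), so in this assay the methyl is not required at this place on the aromatic ring, and the change is the first shown from compound 1 that lowers the number. The methoxy replaced by hydrogen in compound 3 is a different one from the methoxy changed in compound 4, so a 41-fold higher number from compound 1 to compound 3 (1.61 log units; beyond the scatter) and this new step describe two separate places on the ring rather than a large and a small edit of one group. The data shown offer no measured explanation for why removing this methyl lowers the number.

On these data alone, whether the oxygen itself is needed at this place remains open, since hydrogen, fluorine or an amine there would be required to separate its contribution from that of the hydroxy. It is also unknown how a longer chain on this oxygen, such as ethoxy, would behave, or whether the other methoxy would respond in the same way if it became a hydroxy.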